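A few compounds are considered here, and "the series" means these few. Any claim that something is new, unique, unknown or untested is made for them only; others in the source may bear on it.

The three compounds share one core and differ only in what sits on the carbonyl carbon and its amide-type nitrogen. Compound 1 `COc1cc(-c2nn(-c3cccc(NC(=O)Nc4ccc(Cl)c(Cl)c4)c3)cc2-c2ccncc2)ccc1Cl` carries a 3,4-dichlorophenyl on that nitrogen; in a functional assay on UACC-257 cells (Homo sapiens) for inhibition, read by sulforhodamine B assay, with a stated time of 48 h (a higher number here means that more compound is tolerated, a lower number that less compound is tolerated), compound 1 reaches only > 50000 nM, which is a boundary of the assay and not a number (the limit of > 50000 nM in this assay, at which 1 of the 2 values shown sits). Compound 2 `COc1cc(-c2nn(-c3cccc(NC(=O)Nc4cccc(C(F)(F)F)c4)c3)cc2-c2ccncc2)ccc1Cl` carries a 3-(trifluoromethyl)phenyl on the same nitrogen, and in this assay compound 2 gives 7580 nM. Within the data shown here, this is the only number in the set; the other value is a limit. Among the measured compounds shown here, the one measured step is an at least 6.5-fold lower number from compound 1 to compound 2 (0.81 log units; beyond the scatter). Compound 3 `COc1cc(-c2nn(-c3cccc(NC(=O)c4ccc(Cl)c(C(F)(F)F)c4)c3)cc2-c2ccncc2)ccc1Cl` differs from compound 2 by 4-chloro-3-(trifluoromethyl)phenyl in place of (3-(trifluoromethyl)phenyl)amino on a carbonyl carbon. For the measured compounds named here, no measured step alters the partner of the carbonyl carbon in this way: the step from compound 1 to compound 2 exchanged one aryl for another on the nitrogen, so it offers no direct guide, and the direction of the present change is open. The step from compound 2 to compound 3 is expected to be about a 1.1-fold higher number from compound 2 to compound 3 (0.02 log units; within the scatter). For compound 3 the estimated value in this assay is 8000 nM, with a likely range from 2000 nM to 35000 nM.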

Compound 3, concentration lethal to 50% of the cells: > 32500 nM
Compound 3 ended at the assay's limit (the forecaster's own chance of this, stated with the estimate: 20%); at least 4.0-fold (0.60 log units) between middle value and limit.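

The partner of the carbonyl carbon matters in this assay, not only the aryl group on the amide-type nitrogen: 4-chloro-3-(trifluoromethyl)phenyl in place of (3-(trifluoromethyl)phenyl)amino gives an at least 4.2-fold higher number from compound 2 to compound 3 (0.63 log units; beyond the scatter), so more compound is tolerated after this change. For compound 3 the result is a limit of the assay and not a number: the limit of > 32500 nM in this assay, at which 1 of the 3 values shown sits. Compound 1 also stands at a limit, so the step between compound 1 and compound 3 cannot be read, and compound 2 remains the only one of the three with a true number in this assay.

This single change removes a nitrogen with its hydrogen-bond donor and also brings in a chlorine, and the compounds shown leave open which of these two differences goes with the higher number. They also give no guide to an oxygen atom or a methylene group in place of that nitrogen, either of which would keep the 3-(trifluoromethyl)phenyl at the same distance from the carbonyl carbon.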